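Swapping methoxy for fluoro on a benzothiazole anilide

The source may hold more compounds than are shown below. What is called first, only, known or untested is meant among the compounds shown, and "the series" means these compounds.

Measured so far:
compound 1 `O=C(Nc1cccc(-c2nc3ccccc3s2)c1)c1cnccc1Cl` gives 12000 nM in an ADME assay on Raji cells (Homo sapiens) for inhibition, with a stated time of 72 h; a higher number here means that more compound is needed for the effect, a lower number that less compound is needed;
compound 2 `COc1ccc(-c2nc3ccccc3s2)cc1NC(=O)c1cnccc1Cl` gives 13000 nM in this assay.

In this assay compound 2 has the highest of the two numbers, and its nearest neighbour is compound 1 at a 1.1-fold higher number from compound 1 to compound 2 (0.03 log units; within the scatter), a gap within the scatter. Compound 3 `O=C(Nc1cc(-c2nc3ccccc3s2)ccc1F)c1cnccc1Cl` differs from compound 2 by fluoro in place of methoxy on an aromatic carbon. Within the data shown here, the only measured step, a 1.1-fold higher number from compound 1 to compound 2 (0.03 log units; within the scatter), touches the same position and is within the scatter, so no change beyond the scatter is expected for compound 3 in this assay, an expected step of a 1.1-fold lower number from compound 2 to compound 3 (0.03 log units; within the scatter). Compound 3 is therefore estimated at 12000 nM, within 4000 nM to 36000 nM.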

Compound 3, half-maximal effective concentration: > 25000 nM
Compound 3 was reported as a limit (the forecaster's own chance of this, stated with the estimate: 15%); at least 2.0-fold (0.31 log units) between middle value and limit.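

Compound 3 carries a limit of the assay, not a number: the limit of > 25000 nM in this assay, at which 1 of the 3 values shown sits.

Even so, fluoro on this aromatic carbon, para to a 1,3-benzothiazol-2-yl group, gives the first step beyond the scatter in this assay: an at least 2.0-fold higher number from compound 1 to compound 3 (0.31 log units; beyond the scatter). Against methoxy the reading is weaker, an at least 1.9-fold higher number from compound 2 to compound 3 (0.28 log units; that floor lies within the scatter), so fluoro and methoxy are not firmly separated at this position.

As far as these compounds go, what stays open is whether this step is particular to fluoro. An amine or a hydroxyl group on the same carbon would show whether other small groups behave like it.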